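Pentyl to methoxy on the aryl ring of compound 3

The compounds below may be only part of what the source reports. "The series", "measured", "known", "first", "only" and "open" are said of these compounds alone.

Measured compounds:
Compound 1 `O=C1O/C(=C\Cn2cc(-c3ccc(Br)cc3)nn2)C(OCc2ccccc2)=C1OCc1ccccc1`: in a functional assay on HCT-116 cells (Homo sapiens) for antiproliferative activity, read by MTT assay, with a stated time of 72 h (a higher number here means a weaker inhibitor, a lower number a stronger inhibitor), compound 1 gives > 100000 nM, which is a limit of the assay and not a number.
Compound 2 `CCCCCc1ccc(-c2cn(C/C=C3\OC(=O)C(OCc4ccccc4)=C3OCc3ccccc3)nn2)cc1`: in this assay compound 2 gives > 100000 nM, again a limit, not a number.
Compound 3 `CCCCCc1ccc(-c2cn(C[C@H](O)[C@H]3OC(=O)C(OCc4ccccc4)=C3OCc3ccccc3)nn2)cc1`: in this assay compound 3 gives 13800 nM.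

Among the measured compounds shown here, compound 3 holds the only number; the other two values sit at the limit of > 100000 nM in this assay, at which 2 of the 3 values shown sit. For the measured compounds named here, the one single-point step, a step that the two limits leave unreadable from compound 1 to compound 2, cannot be read because both ends are limits, so nothing measured bears on the move to compound 4 `COc1ccc(-c2cn(C[C@H](O)[C@H]3OC(=O)C(OCc4ccccc4)=C3OCc3ccccc3)nn2)cc1`. The change is methoxy in place of pentyl on an aromatic carbon. With no readable step on this aryl substituent, the expectation for compound 4 leans on compound 3 alone, with a wide range. The expected step of a 2.2-fold higher number from compound 3 to compound 4 (0.34 log units; beyond the scatter) is taken as a modest loss, and in this assay compound 4 is estimated at 30000 nM, within 7000 nM to 100000 nM.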

Compound 4, half-maximal inhibitory concentration: > 100000 nM
Compound 4: a limit, no number; the forecaster's own chance of this, stated with the estimate: 35%; at least 3.3-fold (0.52 log units) between middle value and limit.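

Among the compounds shown here, with the step from bromo to pentyl unreadable because both ends are limits, this is the first readable change on the aromatic carbon that carries these groups: methoxy in place of pentyl gives an at least 7.2-fold higher number from compound 3 to compound 4 (0.86 log units; beyond the scatter). In this assay compound 4 gives > 100000 nM, which is a limit of the assay and not a number, so the step has a floor but no measured size. Within this pair, the 4-pentylphenyl group keeps a measurable value and the 4-methoxyphenyl group does not, and compound 3 remains the only compound with a number: the limit of > 100000 nM in this assay, at which 3 of the 4 values shown sit.

The compounds shown leave open whether activity follows the length of the carbon chain, as a butyl, hexyl or octyl chain on the same carbon would test. They also leave open how an amine or a carboxylic acid at this place would compare with pentyl.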